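A few compounds are considered here, and "the series" means these few. Any claim that something is new, unique, unknown or untested is made for them only; others in the source may bear on it.

Series notes. In a functional assay on CHO-K1 cells for antagonist activity at melanin-concentrating hormone receptor 1 (Homo sapiens), read by inositol phosphate accumulation, with stated times of 10 min and 45 min (a lower number here means a stronger inhibitor, a higher number a weaker inhibitor), compound 1 `Cc1nc(N(C)C2CCCC2)nc2ccc(NC(=O)/C=C/c3ccc(Cl)cc3)cc12` gives 57 nM. Compound 2 `C/C(=C\C(=O)Nc1ccc2nc(N3CCC(O)CC3)nc(C)c2c1)c1ccc(Cl)cc1` gives 227 nM in this assay. Compound 3 `COCCC1(O)CCN(c2nc(C)c3cc(NC(=O)/C=C/c4ccc(Cl)cc4)ccc3n2)CC1` gives 220 nM in this assay, which places compound 3 second highest of the three numbers, within the scatter of compound 2 and beyond the scatter from compound 1. Going by the values given here, the only measured step is a 3.9-fold higher number from compound 1 to compound 3 (0.59 log units; beyond the scatter), an exchange of the whole amine rather than of a chain end. Compound 4 `CCCC1(O)CCN(c2nc(C)c3cc(NC(=O)/C=C/c4ccc(Cl)cc4)ccc3n2)CC1` differs from compound 3 by methyl in place of methoxy on a saturated chain carbon, two bonds along the chain from a saturated ring carbon. Among the compounds with values here, no measured step bears directly on this change, and the single measured step replaces a far larger fragment, so in this assay the expected step is no change at the digits printed from compound 3 to compound 4 (within the scatter), within the scatter. Compound 4 is estimated at 220 nM, range 110 nM to 440 nM.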

Compound 4, half-maximal inhibitory concentration: 91 nM
Estimate against measurement, compound 4: 2.4-fold (0.38 log units) above; measured number outside the range, below it.
By their numbers in this assay, from the lowest: compounds 1 and 4 (each within the scatter of the next); then compounds 3 and 2 (each within the scatter of the next).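

In this assay the end of the chain counts at this position: methyl in place of methoxy, two bonds along the chain from a saturated ring carbon, gives a 2.4-fold lower number from compound 3 to compound 4 (0.38 log units; beyond the scatter) and is a change of a single end group. The whole-amine exchange now reads differently, since 4-hydroxy-4-propylpiperidin-1-yl in place of cyclopentyl(methyl)amino gives only a 1.6-fold higher number from compound 1 to compound 4 (0.20 log units; within the scatter) and stays within the scatter. No measurement shown offers a reason for the methoxy-to-methyl step. Still open, going by these compounds, is how a longer chain such as butyl, or an amine at the chain end, would compare with the propyl chain.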